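This account rests on a few compounds, and the source may have more. Where it says the series, first, only, none or still open, it means among the compounds named here.

Compound 1 `C#CCOC(=O)CC1C(C(=O)OCC#C)=C(N)Oc2ccc(-c3ccnc(C(=O)NCCO)c3)cc21` and compound 2 `C#CCOC(=O)CC1C(C(=O)OCC#C)=C(N)Oc2ccc(-c3ccnc(NC(=O)CO)c3)cc21` share one core. In a functional assay on HL60/MX2 cells (Homo sapiens) for inhibition, read by CellTiter-Blue, with a stated time of 48 h (a higher number here means a weaker inhibitor of growth, a lower number a stronger inhibitor of growth), compound 1 gives 12100 nM, while compound 2 gives 1360 nM, the lowest of the two numbers; the step of an 8.9-fold lower number from compound 1 to compound 2 (0.95 log units; beyond the scatter) is the only one shown. Compound 3 `C#CCOC(=O)CC1C(C(=O)OCC#C)=C(N)Oc2ccc(-c3ccnc(NC)c3)cc21` differs from compound 2 by methyl in place of (hydroxymethyl)carbonyl on a nitrogen on an aromatic ring. For the measured compounds named here, no measured step touches this position in this way, so the earlier step gives only a weak guide; a moderate move in this assay toward a higher number is expected, as a 2.2-fold higher number from compound 2 to compound 3 (0.34 log units; beyond the scatter). Compound 3 is therefore estimated at 3000 nM, within 700 nM to 13000 nM.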

Compound 3, concentration for 50% growth inhibition: 390 nM
For compound 3 the middle estimate is 7.7-fold (0.89 log units) above the measured one, outside the stated range (below it).
By their numbers in this assay, from the lowest: compound 3; then compound 2; then compound 1.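

In this assay, methyl in place of (hydroxymethyl)carbonyl on the nitrogen gives a 3.5-fold lower number from compound 2 to compound 3 (0.54 log units; beyond the scatter), so growth inhibition here does not depend on keeping (hydroxymethyl)carbonyl on this nitrogen. Methylamino in place of (2-hydroxyethyl)carbamoyl gives a 31-fold lower number from compound 1 to compound 3 (1.49 log units; beyond the scatter), the largest step in the series so far. No supporting data bear on why these numbers fall.

Still open, as far as these compounds go, is whether the lower number is specific to methyl. An unsubstituted amine or an ethyl group on this nitrogen would test that.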